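Naphthyl for trifluoromethylphenyl at the chain end

The source may hold more compounds than are shown below. What is called first, only, known or untested is meant among the compounds shown, and "the series" means these compounds.

Measured in a functional assay on L1210 cells (Mus musculus) for inhibition (a higher number here means a weaker inhibitor, a lower number a stronger inhibitor), so far
- compound 1 `CC(=O)CC1C[C@@H](CCCCCCCC#C[C@@H](O)COCCOC[C@@H](O)c2ccc(C(F)(F)F)cc2)OC1=O` at 3300 nM
- compound 2 `CCCCN(CCCC)C(O)(O)COCCOCC(O)(O)C#CCCCCCCC[C@@H]1CC(CC(C)=O)C(=O)O1` at 3900 nM

Compound 1 and compound 2 lie within the scatter of each other, and these two numbers are all that is known so far. Compound 3 (`CC(=O)CC1C[C@@H](CCCCCCCC#C[C@@H](O)COCCOC[C@@H](O)c2ccc3ccccc3c2)OC1=O`) is still unmeasured. The change naphthalen-2-yl in place of 4-(trifluoromethyl)phenyl on a saturated chain carbon bound to an oxygen on a saturated carbon and a saturated chain carbon puts naphthalen-2-yl in place of 4-(trifluoromethyl)phenyl on a saturated chain carbon bound to an oxygen on a saturated carbon and a saturated chain carbon. For the measured compounds named here, no measured step covers this swap. Compound 2 at 3900 nM has another chain end and still lies within the scatter of compound 1, so no shift beyond the scatter is expected in this assay here. The expected step is a 1.1-fold lower number from compound 1 to compound 3 (0.04 log units; within the scatter) by this estimate. For compound 3 the estimated value is 3000 nM with an expected range from 1100 nM to 8000 nM for now.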

Compound 3, half-maximal inhibitory concentration: 2100 nM
For compound 3 the middle estimate is 1.4-fold (0.15 log units) above the measured one; the measured number falls inside the stated range.
By their numbers in this assay, from the lowest: compounds 3, 1 and 2 (each within the scatter of the next).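

In this assay, for the compounds shown here, naphthalen-2-yl in place of 4-(trifluoromethyl)phenyl gives a 1.6-fold lower number from compound 1 to compound 3 (0.20 log units; within the scatter), the only single-place step so far at this chain end. The hydroxy-bearing saturated chain carbon therefore carries either aryl group, one aromatic ring or two, with or without fluorine, and the number stays within the scatter. No supporting data bear on why this holds.

Going by these compounds, whether a carboxylic acid or an unsubstituted phenyl at this position would also stay within the scatter remains open. On these data alone, with one step, the reach of this tolerance is unknown.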